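Cytotoxicity series: nitrogen substituent swap on the lactam ring

A few compounds are considered here, and "the series" means these few. Any claim that something is new, unique, unknown or untested is made for them only; others in the source may bear on it.

Measured so far in a functional assay on HEK293 cells (Homo sapiens) for cytotoxicity; on this read-out higher numbers stand for lower toxicity in this test and lower numbers for higher toxicity in this test:
- compound 1 `COc1ccc([C@H]2CC(=O)N(Cc3cccc([N+](=O)[O-])c3)C2)cc1OC1CCCC1` gives > 10000 nM, a limit of this assay
- compound 2 `COc1ccc([C@H]2CC(=O)N(c3cccc(N)c3C)C2)cc1OC1CCCC1` gives > 10000 nM, also a limit of this assay

Compound 1 stands only at a limit; no number is known for it. Within the data shown here, the one step available, a step that the two limits leave unreadable from compound 1 to compound 2, is unreadable, since (the limit of > 10000 nM in this assay, at which 2 of the 2 values shown sit). Compound 3 `COc1ccc([C@H]2CC(=O)N(c3ccncc3)C2)cc1OC1CCCC1` differs from compound 1 by pyridin-4-yl in place of 3-nitrobenzyl on an amide-type nitrogen in a ring. Among the measured compounds shown here, no measured step bears on this change, so the expected step that the limit leaves unreadable from compound 1 to compound 3 is set at none beyond the scatter. Compound 3 is thus estimated at 15000 nM in this assay, within 5000 nM to 50000 nM, and most likely again reported only as a limit.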

Compound 3, half-maximal cytotoxic concentration: > 10000 nM
Compound 3 gave a limit, no number; the forecaster's own chance of this, stated with the estimate: 80%; the middle value lies beyond the limit too.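

No step can be read among compound 1, compound 2 and compound 3, as all three sit at one limit: the limit of > 10000 nM in this assay, at which 3 of the 3 values shown sit.

The compounds shown leave open whether 3-nitrobenzyl, 3-amino-2-methylphenyl and pyridin-4-yl differ at all in this assay.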